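A Small Amide Change in a Cytotoxicity Series

The source may hold more compounds than are shown below. What is called first, only, known or untested is meant among the compounds shown, and "the series" means these compounds.

Measured so far in an ADME assay on L02 cells (Homo sapiens) for cytotoxicity, read by MTT assay, with a stated time of 48 h; on this read-out higher numbers stand for weaker inhibition and lower numbers for stronger inhibition:
- compound 1 `CCn1c(C(=O)NCCN)ccc1C(CC)(CC)c1ccc(OCC(=O)C(C)(C)C)c(C)c1` gives 2500 nM
- compound 2 `CCOC(=O)CN(C)C(=O)c1ccc(C(CC)(CC)c2ccc(OCC(O)C(C)(C)C)c(C)c2)n1CC` gives 10100 nM
- compound 3 `C#CCNC(=O)c1ccc(C(CC)(CC)c2ccc(OCC(O)C(C)(C)C)c(C)c2)n1CC` gives 4400 nM

The number for compound 3 cannot be told apart from that of compound 1, as the two lie within the usual scatter, while compound 2 gives a clearly higher number. Compound 4 `C=CCN(C)C(=O)c1ccc(C(CC)(CC)c2ccc(OCC(O)C(C)(C)C)c(C)c2)n1CC` keeps the core of compound 3 and changes one group: allyl(methyl)amino in place of propargylamino on a carbonyl carbon. In words, allyl(methyl)amino stands in place of propargylamino on a carbonyl carbon.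

Among the measured compounds shown here, only one measured step touches this carbonyl carbon: a 2.3-fold lower number from compound 2 to compound 3 (0.36 log units; beyond the scatter). It is modest. The group that left in that step carries a methyl on its nitrogen, as allyl(methyl)amino does, so compound 4 might drift back toward a higher number. That step also removed the ester chain, however, and compound 1 differs in more than one place, so the evidence is thin.

The expected change in this assay is small and upward, and the estimate is a 1.3-fold higher number from compound 3 to compound 4 (0.10 log units; within the scatter), which would not stand clear of the scatter. For compound 4 the estimated value is 5500 nM, with an expected range from 2500 nM to 12000 nM.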

Compound 4, half-maximal inhibitory concentration: 6300 nM
Compound 4: the middle estimate sits 1.1-fold (0.06 log units) below what was measured; the measured number falls inside the stated range.
By their numbers in this assay, from the lowest: compounds 1, 3, 4 and 2 (each within the scatter of the next, the first and the last beyond it).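

At this carbonyl carbon, the swap removes the one hydrogen-bond donor of propargylamino, the amide hydrogen, and brings in allyl(methyl)amino with one more heavy atom and a double bond in place of the triple bond, yet in this assay it gives only a small step (a 1.4-fold higher number from compound 3 to compound 4 (0.16 log units; within the scatter)), so the two amides cannot be told apart on this read-out. The second new comparison replaces ethoxycarbonyl with vinyl on a saturated chain carbon bound to an amide-type nitrogen and also stays inside the noise (a 1.6-fold lower number from compound 2 to compound 4 (0.20 log units; within the scatter)), which places compound 4 within the scatter of both compound 2 and compound 3, even though those two stand apart. No measurement here explains why these amides give such similar numbers.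

The step from compound 3 to compound 4 changes the methyl on the nitrogen and the unsaturated chain together, so a plain allylamino group or an N-methyl propargylamino group would be needed to separate those two changes. Among the compounds shown here, how a charged group at this carbonyl carbon, such as a carboxylic acid on the chain or a primary amine like the one in compound 1, would read on the shared core also remains open.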